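Methoxy Addition and Cytotoxicity on A549 Cells

This account rests on a few compounds, and the source may have more. Where it says the series, first, only, none or still open, it means among the compounds named here.

Compound 1 `COc1ccc2[nH]cc(/C=C(\C#N)C(=O)c3c[nH]c4ccccc34)c2c1`: 6600 nM in a functional assay on A549 cells (Homo sapiens) for cytotoxicity, read by WST assay, with a stated time of 24 h; on this read-out lower numbers stand for stronger inhibition and higher numbers for weaker inhibition
Compound 2 `COc1ccc2[nH]cc(/C=C(\C#N)C(=O)c3c[nH]c4ccc(OC)cc34)c2c1`: > 50000 nM in this assay, a limit of the assay
Compound 3 `N#C/C(=C\c1c[nH]c2cc(F)ccc12)C(=O)c1c[nH]c2ccccc12`: 17000 nM in this assay

Compound 1 and compound 2 differ in one place: methoxy in place of hydrogen on an aromatic carbon. That change gave an at least 7.5-fold higher number from compound 1 to compound 2 (0.87 log units; beyond the scatter), the value of compound 2 sitting at the limit of > 50000 nM in this assay, at which 1 of the 3 values shown sits. How the core of compound 3 differs from that of compound 1 is not broken down here; compound 3 simply gives the higher number of the two.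

Compound 4 `COc1ccc2[nH]cc(C(=O)/C(C#N)=C/c3c[nH]c4cc(F)ccc34)c2c1` stands to compound 3 exactly as compound 2 stands to compound 1: methoxy in place of hydrogen on an aromatic carbon, the same change at the same place. The step is expected to repeat as a 3.5-fold higher number from compound 3 to compound 4 (0.55 log units; beyond the scatter), resting on an at least 7.5-fold higher number from compound 1 to compound 2 (0.87 log units; beyond the scatter). Compound 4 is therefore estimated at 60000 nM in this assay. Its range is expected to run from 25000 nM to 200000 nM.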

Compound 4, half-maximal inhibitory concentration: > 50000 nM
Compound 4 was reported as a limit; the forecaster's own chance of this, stated with the estimate: 70%; the middle value is on the limit's open side.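

In this assay, methoxy in place of hydrogen on an aromatic carbon gave an at least 2.9-fold higher number from compound 3 to compound 4 (0.46 log units; beyond the scatter) on this second core. Compound 4 is reported only as a limit of the assay: the limit of > 50000 nM in this assay, at which 2 of the 4 values shown sit. The change moved the number the same way on both cores, but this does not show that the size of the step carries over: the same change on two cores in this assay, an at least 7.5-fold higher number (0.87 log units; beyond the scatter) from compound 1 to compound 2 and an at least 2.9-fold higher number (0.46 log units; beyond the scatter) from compound 3 to compound 4; the limit leaves it open whether they differ.

The compounds shown leave open how other groups at this place, such as an amine, a hydroxyl or a longer alkoxy chain, would read on either core. They also leave open whether methoxy would give a step of the same direction on a third core.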